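Cytotoxicity limits in the shared-core series: compound 3 to 4

The source may hold more compounds than are shown below. What is called first, only, known or untested is meant among the compounds shown, and "the series" means these compounds.

The series is a set of tertiary amines on a common core. Among the compounds with values here, compound 1 `COCOc1ccc(CN(Cc2ccc(C(C)(C)C)cc2)Cc2cc3cc(C)ccc3[nH]c2=O)cc1` gives 6400 nM in a toxicity assay on MDCK cells (Canis lupus familiaris) for cytotoxicity, read by crystal violet staining, with a stated time of 48 h (a higher number here means that more compound is tolerated, a lower number that less compound is tolerated), the only member with a number rather than a limit. Compound 2 `CCCOc1ccc(CN(Cc2ccc(C(C)(C)C)cc2)Cc2cc3cc(C)ccc3[nH]c2=O)cc1` gives in this assay a value reported only as a limit of the assay, > 5000 nM. Compound 3 `Cc1ccc2[nH]c(=O)c(CN(Cc3ccc(OCCO)cc3)Cc3ccc(C(C)(C)C)cc3)cc2c1` likewise gives in this assay only a limit of the assay, > 5000 nM.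

Where compound 3 stands is therefore only partly readable: its value sits at the limit, where 2 of the 3 values shown sit (the limit of > 5000 nM in this assay, at which 2 of the 3 values shown sit), and the three steps within the measured set stay unreadable in size: a step that the limit leaves unreadable from compound 1 to compound 2, a step that the limit leaves unreadable from compound 1 to compound 3 and a step that the two limits leave unreadable from compound 2 to compound 3.

Compound 4 `Cc1ccc2[nH]c(=O)c(CN(Cc3ccc(C(C)(C)C)cc3)[C@@H](C)c3ccc(F)cc3)cc2c1` is the next member. The change from compound 3 is 1-(4-fluorophenyl)ethyl in place of 4-(2-hydroxyethoxy)benzyl on an amine nitrogen. Within the data shown here, none of the three measured steps touches this part of the molecule, and none of them has a readable size, so no measured step bears directly on it. Among the measured compounds shown here, the only readable number, from compound 1, lies close to the limit, and the expectation is that the step that the limit leaves unreadable from compound 3 to compound 4 is not beyond the scatter, with a real chance that only a limit is again reported. Compound 4 is expected to give about 6000 nM in this assay, within 2500 nM to 20000 nM.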

Compound 4, half-maximal cytotoxic concentration: > 5000 nM
Compound 4 gave a limit, no number; the forecaster's own chance of this, stated with the estimate: 60%; the middle value does not contradict the limit.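

In this assay, within the data shown here, compound 4 gives > 5000 nM as a limit of the assay and not a number, so no step from compound 1, compound 2 or compound 3 to compound 4 can be read in size. The compounds shown leave open how compound 2, compound 3 and compound 4 truly stand against compound 1 with so many values at one limit: the limit of > 5000 nM in this assay, at which 3 of the 4 values shown sit.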